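Swapping the amine substituent in a urotensin receptor antagonist series

The source may report more compounds than this note shows. Statements on the series, on what has been measured and on what is new or still open speak of the compounds shown alone.

Compound 1 `CCN1CCN(c2cccc3c2CN([C@H](CCCNC(=O)c2c(C)n[nH]c2C)c2ccc(OC)c(OC)c2)C3=O)CC1` gives 16 nM in a functional assay on CHO-K1 cells for antagonist activity at Urotensin-2 receptor (Rattus norvegicus), read by FLIPR and calcium flux, with a stated time of 1 h; on this read-out higher numbers stand for weaker inhibition and lower numbers for stronger inhibition.
Compound 2 `CCN1CCN(c2cccc3c2CN([C@H](CCCN(C)S(=O)(=O)c2cccs2)c2ccc(OC)c(OC)c2)C3=O)CC1` gives 7 nM in this assay.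
Compound 3 `CCN1CCN(c2cccc3c2CN([C@H](CCCNCc2cccs2)c2ccc(OC)c(OC)c2)C3=O)CC1` gives 6 nM in this assay.

Compound 3 has the lowest number of the three, but its gap to compound 2 is within the scatter; only compound 1 stands clearly apart. Compound 4 `CCN1CCN(c2cccc3c2CN([C@H](CCCNc2cncc(OC)n2)c2ccc(OC)c(OC)c2)C3=O)CC1` carries 6-methoxypyrazin-2-yl in place of (thiophen-2-yl)methyl on an amine nitrogen. Going by the values given here, two measured steps touch this position: a 2.7-fold lower number from compound 1 to compound 3 (0.43 log units; beyond the scatter) and a 1.2-fold lower number from compound 2 to compound 3 (0.07 log units; within the scatter), so different groups here have moved the number only modestly. The step of a 1.7-fold higher number from compound 3 to compound 4 (0.22 log units; within the scatter) is therefore expected to be small, at most slightly upward. Compound 4 is estimated at 10 nM, in a range of 4 nM to 30 nM.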

Compound 4, half-maximal inhibitory concentration: 4 nM
Compound 4: the middle estimate sits 2.5-fold (0.40 log units) above what was measured, and the stated range covers the measured number.
By their numbers in this assay, from the lowest: compounds 4, 3 and 2 (each within the scatter of the next); then compound 1.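

With an aromatic ring placed directly on the amine nitrogen, the number in this assay stays close to those with sulfur-containing groups: a 1.5-fold lower number from compound 3 to compound 4 (0.18 log units; within the scatter) and a 1.8-fold lower number from compound 2 to compound 4 (0.24 log units; within the scatter) both remain within the scatter. The contrast with the pyrazole amide is larger, with a 4.0-fold lower number from compound 1 to compound 4 (0.60 log units; beyond the scatter), which lies beyond it. This position therefore accepts a 6-methoxypyrazin-2-yl group as readily as a (thiophen-2-yl)methyl group. Going by these compounds, what the methoxy group itself contributes remains open, and a plain pyrazin-2-yl or phenyl group on this nitrogen would help to separate it from the ring. No measurement shown gives a reason for these numbers.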